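Swapping a phenyl for a methoxy on the ring

A few compounds are considered here, and "the series" means these few. Any claim that something is new, unique, unknown or untested is made for them only; others in the source may bear on it.

Measured so far:
compound 1 `N#Cc1cnc(NCc2ccccc2)cc1N[C@H]1CC[C@@H](O)CC1` 7000 nM
compound 2 `N#Cc1cnc(NCc2cncnc2-c2ccccc2)cc1N[C@H]1CC[C@@H](O)CC1` 90 nM

In an assay on isolated protein for inhibition of protein kinase C theta type (Homo sapiens), read by TR-FRET, with a stated time of 2 h (on this read-out higher numbers stand for weaker inhibition and lower numbers for stronger inhibition), compound 1 gives 7000 nM, while compound 2 gives 90 nM. Compound 2 thus holds the lowest of the two numbers, and the gap to compound 1 is far beyond the scatter of this assay. Compound 3 `COc1ncncc1CNc1cc(N[C@H]2CC[C@@H](O)CC2)c(C#N)cn1` has not yet been measured. It differs from compound 2 in one place: methoxy in place of phenyl on an aromatic carbon next to the ring nitrogen. Going by the values given here, there is no measured pair that shows what such a swap does, so the direction of the step cannot be read from the data. Since a much smaller group takes the place of the phenyl, a rise in the number, meaning weaker inhibition, seems more likely than a fall, but of uncertain size. For compound 3 the estimate in this assay is 500 nM, between 100 nM and 2500 nM. That expected step, a 5.6-fold higher number from compound 2 to compound 3 (0.74 log units; beyond the scatter), is a moderate loss.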

Compound 3, half-maximal inhibitory concentration: 800 nM
Estimate against measurement, compound 3: 1.6-fold (0.20 log units) below; the range from low to high includes it.
By their numbers in this assay, from the lowest: compound 2; then compound 3; then compound 1.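

In this assay, putting methoxy in place of phenyl on the aromatic carbon gives an 8.9-fold higher number from compound 2 to compound 3 (0.95 log units; beyond the scatter), so at this place on the ring, methoxy does not match what phenyl achieves. Even so, the step with 4-methoxypyrimidin-5-yl in place of phenyl on the chain carbon is an 8.8-fold lower number from compound 1 to compound 3 (0.94 log units; beyond the scatter), which shows that compound 3 keeps part of the advantage over compound 1 and that phenyl is not the only group here compatible with a better number than compound 1 has. Nothing measured here explains either step.

The compounds shown leave open how the pyrimidine ring would fare with only a hydrogen on this carbon. They also leave open whether a cyclopropyl, a dimethylamino group or a pyridine ring at this place would come closer to phenyl.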